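Adding a second methoxy group: from compound 3 to compound 4

The compounds below may be only part of what the source reports. "The series", "measured", "known", "first", "only" and "open" are said of these compounds alone.

Measured compounds:
compound 1 `COc1ccc(S(=O)(=O)c2cnc3cc(F)ccc3c2N2CCC(C)CC2)cc1OC` 83%
compound 2 `CC1CCN(c2c(S(=O)(=O)c3ccc(C#N)cc3)cnc3cc(Cl)ccc23)CC1` 70%
compound 3 `COc1cccc(S(=O)(=O)c2cnc3cc(Cl)ccc3c2N2CCC(C)CC2)c1` 93%

In an assay on isolated protein for displacement of a labelled ligand from metabotropic glutamate receptor 5 (Homo sapiens), with a stated time of 60 min, tested at 1 uM (on this read-out lower numbers stand for less inhibition and higher numbers for more inhibition at the one concentration tested (going by the name of the read-out)), compound 3 stands highest of the three numbers. Its nearest neighbour is compound 1, which in this assay gives 83%, a gap that lies within the usual scatter of repeated measurements, so the two cannot be ranked. Furthest away is compound 2 with 70%; the one single-point step in this set, a number 23 percentage points higher from compound 2 to compound 3 (beyond the scatter), is beyond the scatter and modest in size.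

Compound 4 `COc1ccc(S(=O)(=O)c2cnc3cc(Cl)ccc3c2N2CCC(C)CC2)cc1OC` is not yet measured. It differs from compound 3 in one place: methoxy in place of hydrogen on an aromatic carbon. For the measured compounds named here, no measured step bears directly on this change, since the only step in hand exchanges the whole aryl group on the sulfonyl sulfur rather than adding a methoxy group. The closest guide is compound 1, which carries the same 3,4-dimethoxyphenyl group and gives a number within the scatter of compound 3. On that basis the expected step of a number 5 percentage points lower from compound 3 to compound 4 (within the scatter) is none beyond the scatter, in either direction. Compound 4 is therefore estimated at 88%, with a range from 75% to 97%.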

Compound 4, a percentage reported as inhibition, at one concentration (the size of the read-out at that concentration, not a potency): 93%
Estimate against measurement, compound 4: 5 percentage points below; the range from low to high includes it.
By their numbers in this assay, from the lowest: compound 2; then compounds 1, 3 and 4 (each within the scatter of the next).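

In this assay, the step of no change at the digits printed from compound 3 to compound 4 (within the scatter) shows that methoxy in place of hydrogen on this aromatic carbon, ortho to a methoxy group and para to a large group, leaves the read-out unchanged. With chloro on the core, the 3,4-dimethoxyphenyl group can now be set against 4-cyanophenyl, giving a number 23 percentage points higher from compound 2 to compound 4 (beyond the scatter), while chloro in place of fluoro gives a number 10 percentage points higher from compound 1 to compound 4 (within the scatter), so this halogen exchange shows no difference that can be read. Nothing measured here offers an explanation for these results.

Since this assay reports a single concentration, these figures do not show whether compound 3 and compound 4 would differ in potency. As far as these compounds go, it also remains open whether a hydroxy group, an ethoxy group or an amine would be accommodated on this aromatic carbon as the methoxy group is.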